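This account rests on a few compounds, and the source may have more. Where it says the series, first, only, none or still open, it means among the compounds named here.

Measured so far in a functional assay on PC-3 cells (Homo sapiens) for antiproliferative activity, read by MTT assay, with a stated time of 48 h; on this read-out lower numbers stand for stronger inhibition and higher numbers for weaker inhibition:
- compound 1 `NS(=O)(=O)c1ccc(Nc2ncc(F)c(Nc3nc4ccccc4s3)n2)cc1`: > 50000 nM, a limit of the assay rather than a number.
- compound 2 `Cc1ccc2nc(Nc3ccnc(Nc4ccc(S(C)(=O)=O)cc4)n3)sc2c1`: > 50000 nM, likewise a limit.

Compound 1 stands at the assay limit, and the other value shown is also a limit, so no order between the two can be read. Compound 3 `Cc1cnc(Nc2ccc(S(N)(=O)=O)cc2)nc1Nc1nc2ccccc2s1` is not yet measured; it differs from compound 1 by methyl in place of fluoro on an aromatic carbon. Among the compounds with values here, no step between measured compounds is available, so the expected move in this assay rests on the change alone; given (the limit of > 50000 nM in this assay, at which 2 of the 2 values shown sit), no shift beyond the scatter is expected, and a limit again is the likeliest outcome. Compound 3 is estimated at 50000 nM, within 15000 nM to 150000 nM. The expected step is a number no higher from compound 1 to compound 3 (the limit leaves the size open).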

Compound 3, half-maximal inhibitory concentration: > 50000 nM
Compound 3 ended at the assay's limit; the forecaster's own chance of this, stated with the estimate: 75%; the middle value sits exactly at the limit.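

No step can be read from compound 1 to compound 3, as both results are limits of the assay. The compounds shown leave open whether methyl or fluoro at this place changes activity, and how any of them ranks: the limit of > 50000 nM in this assay, at which 3 of the 3 values shown sit.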